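The source may report more compounds than this note shows. Statements on the series, on what has been measured and on what is new or still open speak of the compounds shown alone.

Measured so far, in a functional assay on SK-OV-3 cells (Homo sapiens) for antiproliferative activity, read by MTT assay, with a stated time of 24 h; on this read-out higher numbers stand for weaker inhibition and lower numbers for stronger inhibition:
compound 1 `COc1ccc(C(=O)/C=C/c2ccc([N+](=O)[O-])cc2)c2c1C=CC(C)(C)O2`, 3420 nM
compound 2 `COc1ccc(C(=O)/C=C/c2ccccn2)c2c1C=CC(C)(C)O2`, 8390 nM

Among the measured compounds shown here, compound 2 gives the higher of these two numbers, and the only step measured is the one from compound 1 to it: a 2.5-fold higher number from compound 1 to compound 2 (0.39 log units; beyond the scatter). Compound 3 `COc1ccccc1/C=C/C(=O)c1ccc(OC)c2c1OC(C)(C)C=C2` is not yet measured. It differs from compound 2 in one place: 2-methoxyphenyl in place of pyridin-2-yl on a double-bonded chain carbon bound to a double-bonded chain carbon.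

For the measured compounds named here, the single measured step bears on this change only loosely, since it swaps one ring for another at the same place and was modest in size. Going by the values given here, no measured step involves 2-methoxyphenyl itself. The expectation is therefore a small step for compound 3, a 1.7-fold lower number from compound 2 to compound 3 (0.22 log units; within the scatter), with wide uncertainty in both directions. For compound 3 in this assay the estimate is 5000 nM, with a range from 1500 nM to 16000 nM.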

Compound 3, half-maximal inhibitory concentration: > 10000 nM
Compound 3 was reported as a limit; the forecaster's own chance of this, stated with the estimate: 10%; middle value at least 2.0-fold (0.30 log units) away from the limit.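

In this assay compound 3 gives > 10000 nM, which is a limit of the assay and not a number: the limit of > 10000 nM in this assay, at which 1 of the 3 values shown sits. The change from pyridin-2-yl to 2-methoxyphenyl is an at least 1.1-fold higher number from compound 2 to compound 3 (0.07 log units; that floor lies within the scatter), so this step alone cannot separate the two rings, although it shows no gain from the swap. The change from 4-nitrophenyl to 2-methoxyphenyl is clearer, an at least 2.9-fold higher number from compound 1 to compound 3 (0.46 log units; beyond the scatter), and it shows that the ring at this place on the chain can move the read-out by more than the earlier modest step showed, with 4-nitrophenyl giving the lowest number of the three.

As far as these compounds go, how far the true number for 2-methoxyphenyl lies past the limit remains open. So does the outcome with an unsubstituted phenyl ring or a ring carrying an amine or a carboxylic acid at this place.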